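Swapping One Halogen for Another on an Aromatic Ring

The compounds below may be only part of what the source reports. "The series", "measured", "known", "first", "only" and "open" are said of these compounds alone.

Of the compounds shown here, two have been measured in a functional assay on the whole organism (Ear) for inhibition, with Mus musculus as the target, with a stated time of 30 min, at a dose of 100 mg/kg by the intraperitoneal route; on this read-out lower numbers stand for less inhibition and higher numbers for more inhibition at the one dose given (going by the name of the read-out). Compound 1 `N=C(N)N/N=C/c1ccc(/C=C/C(=O)c2ccc(Cl)cc2Cl)cc1` gives 92.5% in this assay, and compound 2 `N=C(N)N/N=C/c1ccc(/C=C/C(=O)c2ccccc2Br)cc1` gives 78.3%. Compound 2 therefore stands lowest of the two numbers, with compound 1 the nearest and higher, and the difference a number 14.2 percentage points lower from compound 1 to compound 2 (beyond the scatter) came with the exchange of 2-bromophenyl for 2,4-dichlorophenyl on a carbonyl carbon.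

Compound 3 `N=C(N)N/N=C/c1ccc(/C=C/C(=O)c2ccccc2F)cc1` has not been measured. It differs from compound 2 in one place: fluoro in place of bromo on an aromatic carbon. Among the compounds with values here, the only measured step, from compound 1 to compound 2, changed two chlorines into one bromine and is a different kind of change, so it bears on this step only loosely; it shows that altering the halogens on this ring can move the number by a modest amount. Within the data shown here, a halogen-for-halogen swap of this sort has no measured counterpart here. The expected step of a number 6.3 percentage points lower from compound 2 to compound 3 (within the scatter) is therefore small, within the usual scatter, with no firm direction. Compound 3 is expected to give about 72% in this assay, estimated to lie between 52% and 88%.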

Compound 3, a percentage reported as inhibition, in the whole organism at one dose (the size of the read-out at that dose, not a potency): 91.7%
For compound 3 the middle estimate is 19.7 percentage points below the measured one, outside the stated range (above it).
By their numbers in this assay, from the lowest: compound 2; then compounds 3 and 1 (each within the scatter of the next).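

In this assay, the halogen at this place matters on its own: fluoro in place of bromo gives a number 13.4 percentage points higher from compound 2 to compound 3 (beyond the scatter) with the rest of the molecule unchanged, so a swap of one halogen for another can move this number by a modest amount. Comparing the 2-fluorophenyl and 2,4-dichlorophenyl groups gives a number 0.8 percentage points lower from compound 1 to compound 3 (within the scatter) and so does not separate them on this read-out, which shows that among these compounds a single fluoro on this ring can match the two chlorines at the one dose given. The data at hand offer no explanation for the gap between the bromo and fluoro compounds.

As far as these compounds go, whether a 2-chlorophenyl or 2-iodophenyl group would read like the fluoro compound or like the bromo compound remains open, as does the result of placing an amine, a methoxy group or a carboxylic acid at this place on the ring. Also open is whether the step from bromo to fluoro would keep its direction and size at other doses, since what is shown covers a single dose.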